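Two Triazenes Measured for Solubility, a Third Awaited

A few compounds are considered here, and "the series" means these few. Any claim that something is new, unique, unknown or untested is made for them only; others in the source may bear on it.

Measured compounds:
compound 1 `Fc1ccc(/N=N/Nc2ccc(F)cc2F)c(F)c1` gives 186000 nM in a physicochemical assay for solubility; a lower number here means a less soluble compound, a higher number a more soluble compound
compound 2 `COc1cc(/C=C/C(=O)N(/N=N/c2cc(C(F)(F)F)ccc2Cl)c2cc(C(F)(F)F)ccc2Cl)ccc1OC(C)=O` gives 40300 nM in this assay

Compound 2 holds the lower of the two numbers recorded so far; compound 1 stands above it by a gap that lies beyond the scatter of repeated measurements. Among the compounds with values here, no pair of measured compounds differs in only one place, so no single measured step can be drawn on.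

Compound 3 `COc1ccc(/C=C/C(=O)N(/N=N/c2cc(C(F)(F)F)ccc2Cl)c2cc(C(F)(F)F)ccc2Cl)c(OC)c1` is the unmeasured neighbour of compound 2. It differs from compound 2 in one place: 2,4-dimethoxyphenyl in place of 4-acetoxy-3-methoxyphenyl on a double-bonded chain carbon bound to a double-bonded chain carbon. Within the data shown here, with no measured step of this kind available, the expectation for compound 3 rests on the value of compound 2 alone, and the change is expected to move the number modestly, if at all: a small rise, within or only just beyond the scatter, seems the most likely outcome, with a fall not excluded.

The step from compound 2 to compound 3 is expected to be a 1.4-fold higher number from compound 2 to compound 3 (0.14 log units; within the scatter). Compound 3 is therefore estimated to give about 55000 nM, with a plausible range from 20000 nM to 150000 nM.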

Compound 3, solubility: 84400 nM
The estimate for compound 3 lay 1.5-fold (0.19 log units) below the measured number; the range from low to high includes it.
By their numbers in this assay, from the lowest: compound 2; then compound 3; then compound 1.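

In this assay, 2,4-dimethoxyphenyl in place of 4-acetoxy-3-methoxyphenyl on a double-bonded chain carbon bound to a double-bonded chain carbon gives a 2.1-fold higher number from compound 2 to compound 3 (0.32 log units; beyond the scatter), a modest step that lies beyond the scatter of repeated measurements. Within the data shown here, this is the first step read at this position, and it shows that the number moves when one substituted phenyl group replaces another while the rest of compound 2 stays the same; the entering group has fewer heavy atoms than the leaving group and 2 hydrogen-bond acceptors against 3. No measurement shown here accounts for the rise in the number.

The compounds shown leave open which part of the change carries the step: the loss of the acetoxy group, or the arrangement of the two methoxy groups in 2,4-dimethoxyphenyl. They also leave open how the number would respond at this position to a phenyl group bearing a morpholine or a carboxylic acid.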